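A few compounds are considered here, and "the series" means these few. Any claim that something is new, unique, unknown or untested is made for them only; others in the source may bear on it.

In a functional assay on MGC-803 cells (Homo sapiens) for inhibition, read by MTT assay, with a stated time of 48 h (a higher number here means a weaker inhibitor, a lower number a stronger inhibitor), the measured compounds read as follows:

- compound 1 `CCCCC(=O)N(Cc1ccc(OC)c(O)c1)c1cc(OC)c(OC)c(OC)c1` gives 66 nM
- compound 2 `COCC(=O)N(Cc1ccc(OC)c(O)c1)c1cc(OC)c(OC)c(OC)c1` gives 79 nM
- compound 3 `C/C=C/C(=O)N(Cc1ccc(OC)c(O)c1)c1cc(OC)c(OC)c(OC)c1` gives 27 nM

The steps of a 2.4-fold lower number from compound 1 to compound 3 (0.39 log units; beyond the scatter) and a 2.9-fold lower number from compound 2 to compound 3 (0.47 log units; beyond the scatter) leave compound 3 with the lowest number of the three. Compound 4 `COc1ccc(CN(C(=O)/C=C/CBr)c2cc(OC)c(OC)c(OC)c2)cc1O` differs from compound 3 by one change (bromo in place of hydrogen on a saturated chain carbon bound to a double-bonded chain carbon) with bromo in place of hydrogen on a saturated chain carbon bound to a double-bonded chain carbon. Among the compounds with values here, no measured step makes this exchange, so the data give no direction. The nearest evidence is a 2.9-fold lower number from compound 2 to compound 3 (0.47 log units; beyond the scatter) and it is modest, so in this assay a step no larger than modest is expected, quite possibly none beyond the scatter. Compound 4 is expected at 25 nM with an estimated range of 8 nM to 80 nM around that figure. The expected step is a 1.1-fold lower number from compound 3 to compound 4 (0.03 log units; within the scatter) by this estimate.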

Compound 4, half-maximal inhibitory concentration: 71 nM
Estimate against measurement, compound 4: 2.8-fold (0.45 log units) below; low and high end bracket the measured number.
By their numbers in this assay, from the lowest: compound 3; then compounds 1, 4 and 2 (each within the scatter of the next).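

Bromo in place of hydrogen on the saturated chain carbon bound to a double-bonded chain carbon is the first change at this position, and in this assay it goes beyond the scatter (a 2.6-fold higher number from compound 3 to compound 4 (0.42 log units; beyond the scatter)). The edge that prop-1-en-1-yl held over butyl and methoxymethyl is gone with 3-bromoprop-1-en-1-yl (a 1.1-fold higher number from compound 1 to compound 4 (0.03 log units; within the scatter); a 1.1-fold lower number from compound 2 to compound 4 (0.05 log units; within the scatter)), both steps lying within the scatter. Nothing shown gives a measured reason for this step. The compounds shown leave open how a chloro, a hydroxyl or an amine would read on that same carbon.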